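The source may report more compounds than this note shows. Statements on the series, on what has been measured and on what is new or still open speak of the compounds shown alone.

Compound 2, `COc1cccc(-c2nc(SCC(=O)c3sc(-c4ccccc4)nc3C)[nH]c(=O)c2C#N)c1`, gives 21.8% in a functional assay on U-87MG ATCC cells for antiproliferative activity against U-87 MG (Homo sapiens), read by MTT assay, with a stated time of 48 h, tested at 100 uM (a higher number here means a weaker effect of the compound at the concentration tested, a lower number a stronger effect), the highest of the three numbers measured. Compound 1, `COc1ccc(-c2nc(SCC(=O)c3sc(-c4ccccc4)nc3C)[nH]c(=O)c2C#N)cc1`, gives 1.08%, and compound 3, `Cc1nc(-c2ccccc2)sc1C(=O)CSc1nc(-c2ccccc2)c(C#N)c(=O)[nH]1`, gives 9.23%. The steps seen so far are a number 20.7 percentage points higher from compound 1 to compound 2 (beyond the scatter) and a number 12.6 percentage points lower from compound 2 to compound 3 (beyond the scatter); both concern the methoxy-bearing ring, not the ring altered here. Compound 4, `COc1cccc(-c2nc(SCC(=O)c3sc(-c4ccc(Cl)cc4)nc3C)[nH]c(=O)c2C#N)c1`, differs from compound 2 by chloro in place of hydrogen on an aromatic carbon. Going by the values given here, no measured step bears on this change, so no step beyond the scatter is expected in this assay, and the number for compound 4 is expected to lie near that of compound 2, the expected step being a number 1.8 percentage points lower from compound 2 to compound 4 (within the scatter). The estimate for compound 4 is 20%, between 5% and 40%.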

Compound 4, a percentage reported as activity, at one concentration (the size of the read-out at that concentration, not a potency): 8.54%
The estimate for compound 4 lay 11.5 percentage points above the measured number, and the stated range covers the measured number.
By their numbers in this assay, from the lowest: compounds 1, 4 and 3 (each within the scatter of the next); then compound 2.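

In this assay, going by these compounds alone, the change from phenyl to 4-chlorophenyl gives a number 13.3 percentage points lower from compound 2 to compound 4 (beyond the scatter), the first sign that this ring, untouched in the earlier compounds, also affects the read-out. Chloro in place of hydrogen here goes with a stronger effect at the concentration tested, at least on the background of compound 2. No available evidence accounts for this step. From the compounds shown here alone, whether chloro acts the same way alongside the 4-methoxyphenyl of compound 1 remains open. So does what a fluoro, a methoxy or an amine would give at this place.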